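This account rests on a few compounds, and the source may have more. Where it says the series, first, only, none or still open, it means among the compounds named here.

Compound 2 `N#Cc1cc2c(Oc3ccccc3OCCn3ccc(=O)[nH]c3=O)cccc2o1` stands at the assay limit in an ADME assay on MT2 cells (Homo sapiens) for cytotoxicity, read by MTT assay; a lower number here means that less compound is tolerated, a higher number that more compound is tolerated. In this assay compound 2 gives > 100000 nM, which is a limit rather than a number. Its fluoro counterpart, compound 1 `N#Cc1cc2c(Oc3ccc(F)cc3OCCn3ccc(=O)[nH]c3=O)cccc2o1`, also sits at a limit; in this assay compound 1 gives > 100000 nM. For the measured compounds named here, the one step measured so far, a step that the two limits leave unreadable from compound 1 to compound 2, is therefore of unreadable size, and this is due to the limit of > 100000 nM in this assay, at which 2 of the 2 values shown sit. The unmeasured compound 3 `N#Cc1cc2c(Oc3ccc(Cl)cc3OCCn3ccc(=O)[nH]c3=O)cccc2o1` is reached from compound 2 by chloro in place of hydrogen on an aromatic carbon. Going by the values given here, since the only comparable step offers no readable size, no step beyond the scatter is expected for compound 3 in this assay, and a further limit seems the most likely outcome. Compound 3 is thus expected to give 150000 nM, with a range from 60000 nM to 400000 nM. The step that the limit leaves unreadable from compound 2 to compound 3 is accordingly expected to be small.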

Compound 3, half-maximal cytotoxic concentration: 7000 nM
Compound 3: the middle estimate sits 21-fold (1.33 log units) above what was measured; the whole stated range lies above it.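

In this assay, the aromatic position meta to a large group and para to a large group proves able to change the result: an at least 14-fold lower number from compound 2 to compound 3 (1.15 log units; beyond the scatter) goes with chloro in place of hydrogen, and an at least 14-fold lower number from compound 1 to compound 3 (1.15 log units; beyond the scatter) goes with chloro in place of fluoro. For the compounds shown here, both steps lie beyond the scatter, so at this position chloro parts from both hydrogen and fluoro, and compound 3 is the only compound of the three with a readable number. The earlier pair could not show any such difference, due to the assay limit: the limit of > 100000 nM in this assay, at which 2 of the 3 values shown sit.

The step between compound 1 and compound 2 still cannot be read, so hydrogen and fluoro cannot be placed relative to each other. As far as these compounds go, whether bromo, methyl or trifluoromethyl at this position would go with chloro or stay with hydrogen and fluoro remains open.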